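A few compounds are considered here, and "the series" means these few. Any claim that something is new, unique, unknown or untested is made for them only; others in the source may bear on it.

Measured so far:
compound 1 `Nc1ccccc1NC(=O)c1ccc(CSC(=S)N2CCN(Cc3ccccn3)CC2)cc1` gives 82.4% in a functional assay on A-375 cells (Homo sapiens) for antiproliferative activity, read by CCK-8 assay, with a stated time of 72 h, tested at 8 uM; a lower number here means a weaker effect, a higher number a stronger effect of the compound at the concentration tested
compound 2 `CCN(Cc1ccncc1)C(=S)SCc1ccc(C(=O)Nc2ccccc2N)cc1` gives 86.2% in this assay

Compound 1 carries the smaller of the two numbers, yet its gap to compound 2 lies within the scatter of repeated measurements, so the two compounds cannot be told apart on what has been measured. Both keep the same benzamide-bearing core and differ only in the group carried on the sulfur-bound carbon.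

Compound 3 `Nc1ccccc1NC(=O)c1ccc(CSC(=S)N2CCN(c3cnccn3)CC2)cc1` has not yet been measured. It departs from compound 1 by a single change, (pyrazin-2-yl in place of (pyridin-2-yl)methyl on an amine nitrogen in a ring). The dithiocarbamate, the linking group and the benzamide part are untouched; only the substituent on the ring nitrogen is exchanged.

Going by the values given here, no measured pair shows what this exchange does. With both measured compounds close together, a step of modest size is expected, most likely none beyond the scatter, with a slight downward drift considered somewhat more probable than an upward one. The step from compound 1 to compound 3 is estimated at a number 5.4 percentage points lower from compound 1 to compound 3 (within the scatter). Compound 3 is therefore expected to give 77%, within a range from 58% to 92%.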

Compound 3, a percentage reported as inhibition, at one concentration (the size of the read-out at that concentration, not a potency): 85.8%
The estimate for compound 3 lay 8.8 percentage points below the measured number, and the stated range covers the measured number.
By their numbers in this assay, from the lowest: compounds 1, 3 and 2 (each within the scatter of the next).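

On the amine nitrogen in the six-membered ring, replacing (pyridin-2-yl)methyl with pyrazin-2-yl gives a number 3.4 percentage points higher from compound 1 to compound 3 (within the scatter) in this assay and thus no change that can be told from repeated measurements. Going by these compounds alone, this is the first direct comparison at this position, and it shows that the read-out holds when the leaving group, with its ring of 1 hetero atom and its 1 hydrogen-bond acceptor, gives way to a group with a ring of 2 hetero atoms and 2 hydrogen-bond acceptors. Nothing measured here explains why the read-out holds across this exchange.

Both substituents on this nitrogen are six-membered aromatic rings with nitrogen in the ring, so the compounds shown leave open whether a carboxylic acid, a primary amine or a longer alkyl chain in the same place would keep the read-out at this level. From the compounds shown here alone, it also remains open whether compound 1 and compound 3, which cannot be separated at the single concentration tested, would remain indistinguishable across a range of concentrations.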